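Pyridin-2-yl Amide Variant of a Cinnamyl Piperidine Series

A few compounds are considered here, and "the series" means these few. Any claim that something is new, unique, unknown or untested is made for them only; others in the source may bear on it.

Measured compounds:
compound 1 `CC(C)c1ccc(NC(=O)C2CCN(C/C=C/c3ccccc3)CC2)cc1`, 9100 nM
compound 2 `CN1CCN(c2ccc(NC(=O)C3CCN(C/C=C/c4ccccc4)CC3)cc2)CC1`, 44000 nM
compound 3 `O=C(Nc1cccc2cccnc12)C1CCN(C/C=C/c2ccccc2)CC1`, 34800 nM

In a functional assay on MCF7 cells (Homo sapiens) for inhibition, read by MTT assay, with a stated time of 72 h (a higher number here means a weaker inhibitor, a lower number a stronger inhibitor), compound 1 gives the lowest number of the three; compound 3 gives 34800 nM and compound 2 gives 44000 nM. Compound 4 `O=C(Nc1ccccn1)C1CCN(C/C=C/c2ccccc2)CC1` has not yet been measured. It differs from compound 1 in one place: pyridin-2-yl in place of 4-isopropylphenyl on an amide-type nitrogen. Among the measured compounds shown here, the one measured step, a 4.8-fold higher number from compound 1 to compound 2 (0.68 log units; beyond the scatter), concerns an aromatic carbon substituent rather than the amide nitrogen, so it bears only loosely on the change here. Compound 3, which also carries a nitrogen-bearing aromatic group on the amide nitrogen, gives a higher number than compound 1. Compound 4 is therefore expected to show a modestly higher number, a 3.3-fold higher number from compound 1 to compound 4 (0.52 log units; beyond the scatter). The estimate for compound 4 is 30000 nM, within 10000 nM to 90000 nM.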

Compound 4, half-maximal inhibitory concentration: 67200 nM
Compound 4: middle estimate off by 2.2-fold (0.35 log units), on the low side; measured number inside the range.
By their numbers in this assay, from the lowest: compound 1; then compounds 3, 2 and 4 (each within the scatter of the next).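

In this assay, replacing 4-isopropylphenyl with pyridin-2-yl on the amide-type nitrogen gives a 7.4-fold higher number from compound 1 to compound 4 (0.87 log units; beyond the scatter), the first step shown at this position. The change both removes the isopropyl group and brings a ring nitrogen with one hydrogen-bond acceptor, and this single step cannot separate those two differences. Nothing available accounts for the size of the step. Going by these compounds, a plain phenyl group on the amide-type nitrogen would help to separate them, but its number remains open. Also open, on these data alone, is whether an isopropyl group on the pyridine ring would give a number closer to that of compound 1.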